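Benzisoselenazolone-thiadiazoles: a methyl for a fluorine

The compounds below may be only part of what the source reports. "The series", "measured", "known", "first", "only" and "open" are said of these compounds alone.

Of the compounds shown here, three of a shared core have been measured in a functional assay on SSMC-7721 cells (Homo sapiens) for antiproliferative activity, read by CCK-8 assay, with a stated time of 48 h; a higher number here means a weaker inhibitor, a lower number a stronger inhibitor. Compound 1 `COc1ccc(-c2nnc(-n3[se]c4ccccc4c3=O)s2)cc1` gives 16500 nM. Compound 2 `O=c1c2ccccc2[se]n1-c1nnc(-c2ccc(F)cc2)s1` gives 42900 nM, and compound 3 `O=c1c2ccccc2[se]n1-c1nnc(-c2cc([N+](=O)[O-])cc([N+](=O)[O-])c2)s1` gives 21600 nM. Among the compounds with values here, the only one-place step among them is a 2.6-fold higher number from compound 1 to compound 2 (0.41 log units; beyond the scatter). Compound 2 thus sits above compound 1 by a gap beyond the scatter, while its gap to compound 3 lies within the scatter, so no order between compound 2 and compound 3 can be read from these numbers.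

Compound 4 `Cc1cccc(-c2nnc(-n3[se]c4ccccc4c3=O)s2)c1` has not yet been tested. It differs from compound 2 in one place: 3-methylphenyl in place of 4-fluorophenyl on an aromatic carbon. Within the data shown here, no measured step exchanges a methyl for a fluorine at this position, so the only bearing evidence is that the three aryl variants of this core cluster within a narrow band in this assay, with the single measured step, from a methoxy to a fluoro group, being modest. On that basis compound 4 is expected to fall within the same band, with a step of a 1.7-fold lower number from compound 2 to compound 4 (0.23 log units; within the scatter) that is itself uncertain in direction. The estimate for compound 4 in this assay is 25000 nM, with a range from 10000 nM to 60000 nM.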

Compound 4, half-maximal inhibitory concentration: 17800 nM
Beside the measured number, compound 4's estimate is 1.4-fold (0.15 log units) above it; the measured number falls inside the stated range.
By their numbers in this assay, from the lowest: compounds 1, 4, 3 and 2 (each within the scatter of the next, the first and the last beyond it).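

At the aryl place on the five-membered ring, next to the ring nitrogen and the ring sulfur, 3-methylphenyl in place of 4-fluorophenyl gives in this assay a 2.4-fold lower number from compound 2 to compound 4 (0.38 log units; beyond the scatter). This is a second one-place step at this position that lies beyond the scatter, after a 2.6-fold higher number from compound 1 to compound 2 (0.41 log units; beyond the scatter), and in both the 4-fluorophenyl compound carries the higher number, while compound 1 and compound 4 lie within the scatter of each other. The change also shows that two groups matching in heavy-atom count, each a single six-membered aromatic ring of carbon only, can still be told apart in this assay, although no measurement here offers an explanation for the difference.

This step changes both the substituent and where it sits on the phenyl ring, so the compounds shown leave open whether the methyl, its location or the loss of the fluorine accounts for it; 4-methylphenyl and 3-fluorophenyl groups would separate these. They also leave open how an aminophenyl or a carboxyphenyl group at this position would read.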